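A few compounds are considered here, and "the series" means these few. Any claim that something is new, unique, unknown or untested is made for them only; others in the source may bear on it.

Of the compounds shown here, three have been measured in an ADME assay on NIH3T3 cells (Mus musculus) for cytotoxicity, read by MTT assay, with a stated time of 24 h (a higher number here means a weaker inhibitor, a lower number a stronger inhibitor), and a fourth awaits measurement. Compound 1 has the structure `Cc1ccc(-c2nnc(N3CCN(C(=O)CN4CCN(c5ccccc5Cl)CC4)CC3)nc2-c2ccc(C)cc2)cc1`. In this assay compound 1 gives > 859000 nM, which is a limit of the assay and not a number. Compound 2 has the structure `COc1cccc(N2CCN(CC(=O)N3CCN(c4nnc(-c5ccc(C)cc5)c(-c5ccc(C)cc5)n4)CC3)CC2)c1`. In this assay compound 2 gives > 866000 nM, again a limit rather than a number. Compound 3 has the structure `COc1ccc(-c2nnc(N3CCN(C(=O)CN4CCN(c5ccccc5Cl)CC4)CC3)nc2-c2ccc(OC)cc2)cc1`. In this assay compound 3 gives > 814000 nM, which is also a limit.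

The change from compound 1 to compound 2 is 3-methoxyphenyl in place of 2-chlorophenyl on an amine nitrogen in a ring, and the step it made is a step that the two limits leave unreadable from compound 1 to compound 2; the size cannot be read because the limit of > 859000 nM in this assay, at which 1 of the 3 values shown sits, and the limit of > 866000 nM in this assay, at which 1 of the 3 values shown sits, are all that the two ends of the step offer. How the core of compound 3 differs from the core of compound 1 is not broken down here; the two sentences above show only that both sit at limits.

Compound 4, with the structure `COc1ccc(-c2nnc(N3CCN(C(=O)CN4CCN(c5cccc(OC)c5)CC4)CC3)nc2-c2ccc(OC)cc2)cc1`, differs from compound 3 by 3-methoxyphenyl in place of 2-chlorophenyl on an amine nitrogen in a ring, the same change as from compound 1 to compound 2, made at the same place. The step in this assay from compound 3 to compound 4 is expected to be a step that the limit leaves unreadable from compound 3 to compound 4, which rests on compound 3 sitting at the limit of > 814000 nM in this assay, at which 1 of the 3 values shown sits, and on the earlier pair of the same change both sitting at limits. For compound 4 the expected value in this assay is 900000 nM, estimated to lie between 400000 nM and 2500000 nM, with the assay most likely again reporting only a limit.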

Compound 4, half-maximal inhibitory concentration: > 821000 nM
Compound 4: no number, only a limit; the forecaster's own chance of this, stated with the estimate: 90%; the middle value lies beyond the limit too.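

No step can be read from compound 3 to compound 4: in this assay both give only limits and not numbers, as do compound 1 and compound 2. The compounds shown leave open whether 3-methoxyphenyl in place of 2-chlorophenyl on an amine nitrogen in a ring changes this read-out at all, and what number any of the four compounds would give.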